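Replacing the 6-methoxypyridin-3-yl group of compound 3

The compounds below may be only part of what the source reports. "The series", "measured", "known", "first", "only" and "open" are said of these compounds alone.

Measured in a functional assay on SW-620 cells (Homo sapiens) for antiproliferative activity, read by MTT assay, with a stated time of 24 h; on this read-out lower numbers stand for stronger inhibition and higher numbers for weaker inhibition:
- compound 1 `COc1cc(OC)c(OC)cc1/C=C/C(=O)c1ccc(OC)c2c1OC(C)(C)C=C2`: > 10000 nM
- compound 2 `COc1ccc(C(=O)/C=C/c2cccc([N+](=O)[O-])c2)c2c1C=CC(C)(C)O2`: 4090 nM
- compound 3 `COc1ccc(/C=C/C(=O)c2ccc(OC)c3c2OC(C)(C)C=C3)cn1`: > 10000 nM

Compound 3 stands at > 10000 nM, which is a limit and not a number. The series shows (the limit of > 10000 nM in this assay, at which 2 of the 3 values shown sit). Only compound 2 gives a true number, 4090 nM.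

Compound 4 `COc1ccc(C(=O)/C=C/c2ccccc2Cl)c2c1C=CC(C)(C)O2` differs from compound 3 in one place: 2-chlorophenyl in place of 6-methoxypyridin-3-yl on a double-bonded chain carbon bound to a double-bonded chain carbon. It carries 2-chlorophenyl in place of 6-methoxypyridin-3-yl on a double-bonded chain carbon bound to a double-bonded chain carbon.

Among the compounds with values here, one measured step bears on this change, made at the same place: an at least 2.4-fold higher number from compound 2 to compound 3 (0.38 log units; beyond the scatter). Read in reverse, it suggests that losing the 6-methoxypyridin-3-yl may lower the number in this assay. Compound 1 goes against any simple reading, since its aromatic ring is also of carbon only and it reads > 10000 nM, again a limit.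

Only a modest move to a lower number is therefore expected, namely an at least 1.8-fold lower number from compound 3 to compound 4 (0.25 log units; that floor lies within the scatter). For compound 4 the estimated value is 5500 nM, with an expected range of 1800 nM to 10000 nM.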

Compound 4, half-maximal inhibitory concentration: > 10000 nM
Compound 4: only a limit was reported; the forecaster's own chance of this, stated with the estimate: 30%; at least 1.8-fold (0.25 log units) between middle value and limit.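

Compound 4 reads > 10000 nM in this assay, again a limit. At this place, on a double-bonded chain carbon bound to a double-bonded chain carbon, 2-chlorophenyl in place of 3-nitrophenyl gives an at least 2.4-fold higher number from compound 2 to compound 4 (0.38 log units; beyond the scatter), so a second group, one with a ring of carbon only, also fails to keep the measurable value of compound 2, as 6-methoxypyridin-3-yl did. The step between compound 3 and compound 4 cannot be read, as both values are limits, and the series now gathers at one end of the assay: the limit of > 10000 nM in this assay, at which 3 of the 4 values shown sit.

Going by these compounds, how a phenyl ring carrying an amine or a carboxylic acid in place of the nitro group would read at this place remains open. Also open, on these data alone, is whether 3-nitrophenyl is alone in giving a true number here.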